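A few compounds are considered here, and "the series" means these few. Any claim that something is new, unique, unknown or untested is made for them only; others in the source may bear on it.

Working notes on the series. Compound 1 `CCC1=C(O)c2c(oc(-c3ccc(SC)cc3)cc2=O)C(CC)(CC)C1=O` gives 1.38 uM in a functional assay on KBVIN cells (Homo sapiens) for antiproliferative activity, read by sulforhodamine B assay, with a stated time of 3 days; a lower number here means that less compound is needed, a higher number that more compound is needed for the effect. Within the data shown here, compound 2 `CCC1=C(O)c2c(oc(-c3ccc(C)c(F)c3)cc2=O)C(CC)(CC)C1=O` gives 2.95 uM in this assay; this is the highest of the two numbers so far, with compound 1 the nearest at a lower number. Among the measured compounds shown here, the only step measured so far, a 2.1-fold higher number from compound 1 to compound 2 (0.33 log units; beyond the scatter), is a swap of the aryl group on the same aromatic carbon as the change now considered. Compound 3 `CCC1=C(O)c2c(oc(-c3cc(C)c(O)c(C)c3)cc2=O)C(CC)(CC)C1=O` differs from compound 2 by 4-hydroxy-3,5-dimethylphenyl in place of 3-fluoro-4-methylphenyl on an aromatic carbon. For the measured compounds named here, no measured compound carries the 4-hydroxy-3,5-dimethylphenyl group, so the one step that bears on this change is the earlier aryl swap, a 2.1-fold higher number from compound 1 to compound 2 (0.33 log units; beyond the scatter), which was modest. A step of comparable modest size is therefore expected here, with the direction not fixed by the numbers at hand, and the estimated step is a 1.2-fold lower number from compound 2 to compound 3 (0.07 log units; within the scatter). For compound 3 in this assay the expected value is 2.5 uM, within a range from 0.8 uM to 8 uM.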

Compound 3, concentration for half-maximal effect: 8.9 uM
For compound 3 the middle estimate is 3.6-fold (0.55 log units) below the measured one; measured number above the stated range.
By their numbers in this assay, from the lowest: compound 1; then compound 2; then compound 3.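

In this assay the 4-hydroxy-3,5-dimethylphenyl group on this aromatic carbon gives a 3.0-fold higher number from compound 2 to compound 3 (0.48 log units; beyond the scatter), and against the 4-(methylsulfanyl)phenyl group it gives a 6.4-fold higher number from compound 1 to compound 3 (0.81 log units; beyond the scatter). Among these compounds, with these steps and the earlier 2.1-fold higher number from compound 1 to compound 2 (0.33 log units; beyond the scatter), all beyond the scatter, the three aryl groups separate into a clear order at this position, with 4-(methylsulfanyl)phenyl lowest, 3-fluoro-4-methylphenyl in the middle and 4-hydroxy-3,5-dimethylphenyl highest, so the choice of aryl group here is not neutral for this read-out, and the only group of the three counted with a hydrogen-bond donor stands at the high end. No measurement at hand gives a reason for this step.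

The change brings in the hydroxy group and a second methyl group and removes the fluorine in a single step, so the compounds shown do not tell which of these goes with the higher number. Also open, on these data alone, is where a 4-hydroxyphenyl group, a 4-methoxy-3,5-dimethylphenyl group or a 4-aminophenyl group on the same carbon would fall in this order.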